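Swapping the aryl group on the hydrazone of compound 2

The compounds below may be only part of what the source reports. "The series", "measured", "known", "first", "only" and "open" are said of these compounds alone.

Measured compounds:
- compound 1, `CN(C)CCn1cnnc1-c1cc(Oc2ccc(NC(=O)N/N=C/c3c(Cl)cccc3Cl)cc2F)ccn1`, > 100000 nM
- compound 2, `CN(C)CCn1cnnc1-c1cc(Oc2ccc(NC(=O)N/N=C/c3ccccc3O[N+](=O)[O-])cc2F)ccn1`, 7150 nM
- compound 3, `CN(C)CCn1cnnc1-c1cc(Oc2ccc(NC(=O)N/N=C/c3cccc(Cl)c3Cl)cc2F)ccn1`, 13200 nM

All three compounds share one core and differ only in the aryl group on a carbon with a double bond to nitrogen. In a functional assay on U-87MG ATCC cells (Homo sapiens) for cytotoxicity, read by MTT assay, with a stated time of 72 h (on this read-out lower numbers stand for stronger inhibition and higher numbers for weaker inhibition), compound 1 gives > 100000 nM, which is a limit of the assay and not a number. In this assay compound 2 gives 7150 nM, the lowest of the two numbers shown, and compound 3 gives 13200 nM; the step of a 1.8-fold higher number from compound 2 to compound 3 (0.27 log units; within the scatter) lies within the scatter, so the two cannot be ordered. The step of an at least 13-fold lower number from compound 1 to compound 2 (1.14 log units; beyond the scatter) and the step of an at least 7.5-fold lower number from compound 1 to compound 3 (0.87 log units; beyond the scatter) show that leaving the 2,6-dichlorophenyl group lowers the number.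

Compound 4, `CN(C)CCn1cnnc1-c1cc(Oc2ccc(NC(=O)N/N=C/c3ccc(O)c(F)c3)cc2F)ccn1`, is not yet measured. It differs from compound 2 as follows: 3-fluoro-4-hydroxyphenyl in place of 2-(nitrooxy)phenyl on a carbon with a double bond to nitrogen. Among the compounds with values here, no measured step changes this same group to a phenyl bearing a hydroxyl and a fluorine, so the closest guide is that the two aryl groups other than 2,6-dichlorophenyl gave numbers within the scatter of each other. The step of a 1.4-fold higher number from compound 2 to compound 4 (0.15 log units; within the scatter) is therefore expected to be small, with the estimate for compound 4 in this assay at 10000 nM, between 3000 nM and 40000 nM.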

Compound 4, half-maximal inhibitory concentration: > 100000 nM
Compound 4 ended at the assay's limit (the forecaster's own chance of this, stated with the estimate: 15%); middle value at least 10-fold (1.00 log units) from the limit.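

In this assay, the change to 3-fluoro-4-hydroxyphenyl on the carbon with a double bond to nitrogen gives an at least 13-fold higher number from compound 2 to compound 4 (1.14 log units; beyond the scatter), and it also gives an at least 7.5-fold higher number from compound 3 to compound 4 (0.87 log units; beyond the scatter). The earlier compounds shown here could be read as saying that any aryl group other than 2,6-dichlorophenyl lowers the number, and compound 4 goes against that reading, so this position is more selective about its aryl group than those compounds showed. Compound 1 and compound 4 both sit at a limit of the assay, so the step between them cannot be read and the two cannot be ordered: the limit of > 100000 nM in this assay, at which 2 of the 4 values shown sit.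

As far as these compounds go, it stays open whether the hydroxyl or the fluorine of the 3-fluoro-4-hydroxyphenyl group goes with the loss of a measurable number. Also open, from the compounds shown here alone, is how an unsubstituted phenyl, or a phenyl carrying an amine or a carboxylic acid, would behave at this position.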